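Methoxy to Methoxycarbonyl: Maximal Response Expected Unchanged

The source may report more compounds than this note shows. Statements on the series, on what has been measured and on what is new or still open speak of the compounds shown alone.

Three compounds share one core and differ only in the group on the ring nitrogen at the far end. Compound 1 `CC(C)(C)OC(=O)N1CCC(CCCNc2ccc3c(c2)OCC3=O)CC1` carries a tert-butoxycarbonyl group and in a functional assay on CHO-K1 cells for agonist activity at Glucose-dependent insulinotropic receptor (Mus musculus), read by HTRF and cAMP accumulation, with a stated time of 30 min (on this read-out lower numbers stand for smaller maximal responses and higher numbers for larger maximal responses), compound 1 gives 108%. Compound 2 `CCc1cnc(N2CCC(CCCNc3ccc4c(c3)OCC4=O)CC2)nc1` carries a 5-ethylpyrimidin-2-yl group, and compound 2 gives 98%. Compound 3 `COc1cnc(N2CCC(CCCNc3ccc4c(c3)OCC4=O)CC2)nc1` carries a 5-methoxypyrimidin-2-yl group, and compound 3 gives 106%. Compound 3 thus stands second highest of the three, with compound 1 nearest and compound 2 furthest, yet every gap is within the scatter: a number 10 percentage points lower from compound 1 to compound 2 (within the scatter), a number 2 percentage points lower from compound 1 to compound 3 (within the scatter) and a number 8 percentage points higher from compound 2 to compound 3 (within the scatter).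

Compound 4 `COC(=O)c1cnc(N2CCC(CCCNc3ccc4c(c3)OCC4=O)CC2)nc1` is not yet measured. The change from compound 3 is methoxycarbonyl in place of methoxy on an aromatic carbon.

The step from compound 2 to compound 3 bears most directly on this, since it also exchanges one group on that aromatic carbon, and it stayed within the scatter. So no step beyond the scatter is expected in this assay, and the expected change is a number 3 percentage points lower from compound 3 to compound 4 (within the scatter). Compound 4 is therefore estimated at 103%, with a range from 88% to 116%.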

Compound 4, largest response reached (Emax), in percent of the reference or control that the assay uses: 67%
Compound 4: middle estimate off by 36 percentage points, on the high side, outside the stated range (below it).
By their numbers in this assay, from the lowest: compound 4; then compounds 2, 3 and 1 (each within the scatter of the next).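

On an aromatic carbon para to a large group, the earlier exchange of ethyl for methoxy stayed within the scatter, but this position does not accept every group equally. In this assay, methoxycarbonyl gives a number 39 percentage points lower from compound 3 to compound 4 (beyond the scatter), and in place of ethyl it gives a number 31 percentage points lower from compound 2 to compound 4 (beyond the scatter), while the whole 5-(methoxycarbonyl)pyrimidin-2-yl group on the ring nitrogen gives a number 41 percentage points lower from compound 1 to compound 4 (beyond the scatter), so compound 4 alone stands clearly apart from the other three. Nothing measured on these compounds accounts for this loss of maximal response.

The compounds shown leave open whether the lower response goes with methoxycarbonyl alone or would also appear with a carboxylic acid, a primary amide or a nitrile on that aromatic carbon. They also leave open whether ethoxycarbonyl there would give a response closer to that of compound 4 or that of compound 3.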